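The source may report more compounds than this note shows. Statements on the series, on what has been measured and on what is new or still open speak of the compounds shown alone.

In a functional assay on HEL cells (Homo sapiens) (on this read-out lower numbers stand for higher toxicity in this test and higher numbers for lower toxicity in this test), compound 1 `C=C(C)C(=O)NC(=O)NC1=CS(=O)(=O)O[C@@]12[C@@H](CO[Si](C)(C)C(C)(C)C)O[C@@H](n1cc(C)c(=O)n(C)c1=O)[C@@H]2O[Si](C)(C)C(C)(C)C` gives 1200 nM and compound 2 `CCNC(=O)NC1=CS(=O)(=O)O[C@@]12[C@@H](CO[Si](C)(C)C(C)(C)C)O[C@@H](n1cc(C)c(=O)n(C)c1=O)[C@@H]2O[Si](C)(C)C(C)(C)C` gives 10000 nM, the higher of these two numbers. Compound 3 `Cc1cn([C@@H]2O[C@H](CO[Si](C)(C)C(C)(C)C)[C@@]3(OS(=O)(=O)C=C3NCCC(N)=O)[C@H]2O[Si](C)(C)C(C)(C)C)c(=O)n(C)c1=O` has the same atoms joined differently: 2-carbamoylethyl in place of ethylcarbamoyl on an amine nitrogen, which means 2-carbamoylethyl in place of ethylcarbamoyl on an amine nitrogen. For the measured compounds named here, only one measured step can serve as a guide, an 8.3-fold higher number from compound 1 to compound 2 (0.92 log units; beyond the scatter), and it also changed the group on this nitrogen. A step of similar or smaller size toward a lower number therefore seems likely. The estimated change is a 2.5-fold lower number from compound 2 to compound 3 (0.40 log units; beyond the scatter). The expected value for compound 3 is 4000 nM, with an estimated range from 1200 nM to 13000 nM.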

Compound 3, half-maximal cytotoxic concentration: 14800 nM
The estimate for compound 3 lay 3.7-fold (0.57 log units) below the measured number; measured number above the stated range.
By their numbers in this assay, from the lowest: compound 1; then compounds 2 and 3 (each within the scatter of the next).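

In this assay, rearranging the same atoms from ethylcarbamoyl to 2-carbamoylethyl on the amine nitrogen gives a 1.5-fold higher number from compound 2 to compound 3 (0.17 log units; within the scatter) and so makes no clear difference. Replacing the ((1-methylethenyl)carbonyl)carbamoyl group of compound 1 with 2-carbamoylethyl gives a 12-fold higher number from compound 1 to compound 3 (1.09 log units; beyond the scatter) and leaves compound 1 as the only one of the three with a clearly lower number. Nothing available here explains either step. On these data alone, whether a carboxylic acid in place of the carbamoyl part of 2-carbamoylethyl, or a longer chain on this nitrogen, would change the number remains open.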